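Nitro for Fluoro on the Phenoxy Arm of Compound 2

A few compounds are considered here, and "the series" means these few. Any claim that something is new, unique, unknown or untested is made for them only; others in the source may bear on it.

Compound 1 `N#Cc1ccccc1C1OCC(C/C=C\CCC(=O)O)C(c2cccnc2)O1` gives in an assay for inhibition of prostacyclin synthase (Homo sapiens), using microsomes (a higher number here means a weaker inhibitor, a lower number a stronger inhibitor), only a limit, > 100000 nM.
Compound 2 `CC(C)(Oc1ccccc1F)C1OCC(C/C=C\CCC(=O)O)C(c2cccnc2)O1` gives in this assay only a limit, < 1000 nM.

Compound 2 stands at the lower edge of what is reported, at the limit of < 1000 nM in this assay, at which 1 of the 2 values shown sits, which is a limit and not a number. Compound 1 sits at the other edge, at the limit of > 100000 nM in this assay, at which 1 of the 2 values shown sits, again a limit. Going by the values given here, the two structures differ in more than one place, so the pair shows only that one value lies at each end of the reported range and nothing about the size of any single change.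

Compound 3 `CC(C)(Oc1ccccc1[N+](=O)[O-])C1OCC(C/C=C\CCC(=O)O)C(c2cccnc2)O1` has not been measured. It differs from compound 2 in one place: nitro in place of fluoro on an aromatic carbon. Among the compounds with values here, no measured step anchors this kind of exchange here, and compound 2 itself is known only as a limit. Compound 3 is therefore expected to move little, with a step that the limit leaves unreadable from compound 2 to compound 3 that may well stay within the scatter, in either direction. Compound 3 is estimated at 600 nM, in the range from 80 nM to 4000 nM.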

Compound 3, half-maximal inhibitory concentration: < 1000 nM
Compound 3 gave a limit, no number; the forecaster's own chance of this, stated with the estimate: 40%; the middle value lies beyond the limit too.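

Compound 2 and compound 3 are both reported in this assay only as limits, so no size can be read for the step of nitro in place of fluoro between them. The compounds shown leave open where either compound's true value lies in this assay, and so whether this exchange shifts it at all, or in which direction.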